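The source may hold more compounds than are shown below. What is called first, only, known or untested is meant among the compounds shown, and "the series" means these compounds.

Measured compounds in an ADME assay on CCRF-CEM cells (Homo sapiens) for cytotoxicity, read by cell counting; on this read-out lower numbers stand for higher toxicity in this test and higher numbers for lower toxicity in this test:

Compound 1 `Cc1cc(C)cc(S(=O)(=O)c2c(C(=O)NCN3CCCCC3)[nH]c3ccc(Cl)c(F)c23)c1` gives 32000 nM.
Compound 2 `Cc1cc(C)cc(S(=O)(=O)c2c(C(=O)NCCOc3ccccc3)[nH]c3ccc(Br)cc23)c1` gives > 500000 nM, which is a limit of this test and not a number.
Compound 3 `Cc1cc(C)cc(S(=O)(=O)c2c(C(=O)NCCOc3ccccc3)[nH]c3ccc(Cl)c(F)c23)c1` gives 11000 nM.

Compounds 1 and 3 share one core; the change between them is piperidin-1-yl in place of phenoxymethyl on a saturated chain carbon bound to an amide-type nitrogen. This step, a 2.9-fold higher number from compound 3 to compound 1 (0.46 log units; beyond the scatter), lowers toxicity in this assay by a modest but real margin.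

Compound 2 carries a different core, and the difference between the two cores is not broken down here. Compound 2 sits at the limit (the limit of > 500000 nM in this assay, at which 1 of the 3 values shown sits), so only a lower bound is known for it.

Compound 4 `Cc1cc(C)cc(S(=O)(=O)c2c(C(=O)NCN3CCCCC3)[nH]c3ccc(Br)cc23)c1` has not yet been measured. It differs from compound 2 by piperidin-1-yl in place of phenoxymethyl on a saturated chain carbon bound to an amide-type nitrogen, the same change that was measured from compound 3 to compound 1. Because the measured step was a 2.9-fold higher number from compound 3 to compound 1 (0.46 log units; beyond the scatter), a shift of similar direction and size, a step that the limit leaves unreadable from compound 2 to compound 4, is expected for compound 4. Since compound 2 already sits at the limit (the limit of > 500000 nM in this assay, at which 1 of the 3 values shown sits), compound 4 is expected to return only a limit as well. The estimate for compound 4 in this assay is 1000000 nM, between 400000 nM and 3000000 nM.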

Compound 4, half-maximal cytotoxic concentration: 10000 nM
Compound 4: the middle estimate sits 100-fold (2.00 log units) above what was measured; measured number below the stated range.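

In this assay, piperidin-1-yl in place of phenoxymethyl gives an at least 50-fold lower number from compound 2 to compound 4 (1.69 log units; beyond the scatter), so the effect of this change on one core does not predict its effect on the other, in size or in direction: the same change on two cores in this assay, a 2.9-fold higher number (0.46 log units; beyond the scatter) from compound 3 to compound 1 and an at least 50-fold lower number (1.69 log units; beyond the scatter) from compound 2 to compound 4, at least 140-fold (2.16 log units) apart, beyond the scatter of two such steps The value of compound 2, > 500000 nM, is a limit of the test and not a number, so the step from it fixes only a minimum size. With one pair on each of two cores, these data show that the outcome of the change depends on the core, but they give neither its cause nor a rule for any other core.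

The compounds shown leave open which part of the difference between the two cores goes with the reversal. They also leave open whether the piperidine ring or the shorter link to the amide nitrogen carries the change, which a 2-(piperidin-1-yl)ethyl group on each core could separate.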